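Fluorine on the benzyl group of compound 1

The source may report more compounds than this note shows. Statements on the series, on what has been measured and on what is new or still open speak of the compounds shown alone.

The series rests on the shared core of compound 1 `O=c1ccc(-c2ccc3cn[nH]c3c2)cn1Cc1ccccc1`, which in an assay for inhibition of MAP kinase-interacting serine/threonine-protein kinase 2 (Homo sapiens), read by luminescence and ADP-Glo, with a stated time of 2 h (a lower number here means a stronger inhibitor, a higher number a weaker inhibitor), gives 75 nM. For the measured compounds named here, of the two numbers measured so far this is the higher; the nearest is compound 2 `Nc1n[nH]c2cc(-c3ccc(=O)n(Cc4ccccc4)c3)ccc12`, which in this assay gives 32 nM. Going by the values given here, the one measured step, a 2.3-fold lower number from compound 1 to compound 2 (0.37 log units; beyond the scatter), comes from an amino in place of hydrogen on an aromatic carbon of the core.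

Compound 3 `O=c1ccc(-c2ccc3cn[nH]c3c2)cn1Cc1ccccc1F` is not yet measured. It differs from compound 1 by fluoro in place of hydrogen on an aromatic carbon. Among the compounds with values here, this change sits on the benzyl group rather than on the core, so the step from compound 1 to compound 2 does not bear on it directly, and no measured step touches the benzyl group at all. The numbers shown therefore carry no expectation of a step beyond the scatter in either direction in this assay, and the working assumption is a number close to that of compound 1.

For compound 3 the expected value in this assay is 75 nM, with a range from 35 nM to 160 nM. The step this implies, no change at the digits printed from compound 1 to compound 3 (within the scatter), is expected to lie within the scatter.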

Compound 3, half-maximal inhibitory concentration: 37 nM
Estimate against measurement, compound 3: 2.0-fold (0.31 log units) above, within the range that was stated.
By their numbers in this assay, from the lowest: compounds 2 and 3 (each within the scatter of the next); then compound 1.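

In this assay, for the compounds shown here, the benzyl group now has a measured step of its own, with a 2.0-fold lower number from compound 1 to compound 3 (0.31 log units; beyond the scatter) as the only evidence on this part of the molecule; the earlier step concerned the core alone. The step is modest, but it shows that this place, on an aromatic carbon of the phenyl ring and ortho to a large group, is not indifferent to substitution: the exchange of phenyl for 2-fluorophenyl adds a single fluorine atom, with no ring, no hydrogen-bond donor or acceptor and no net charge, and the number still moves beyond the scatter. No independent measurement bears on why this exchange lowers the number, so the step stands as an observation only.

Still open, on these data alone, is whether the same place accepts chloro, methyl, methoxy or trifluoromethyl in place of fluoro, and whether a larger group or a carboxylic acid or an amine on the benzyl ring would hold the step, lose it or reverse it. The shown compounds also leave open whether the amino on the core and the fluoro on the benzyl group would add up when carried together on the shared core.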